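The source may report more compounds than this note shows. Statements on the series, on what has been measured and on what is new or still open speak of the compounds shown alone.

Measured compounds:
compound 1, `O=C1c2ccccc2S(=O)(=O)N1CCCCCN1CCN(c2ccccc2)CC1`: 148 nM
compound 2, `O=C1c2ccccc2S(=O)(=O)N1CCCCCCN1CCN(c2ccc(Cl)cc2)CC1`: 487 nM

In an assay on HEK293 cells for displacement of a labelled ligand from 5-hydroxytryptamine receptor 7 (Homo sapiens) (on this read-out higher numbers stand for weaker inhibition and lower numbers for stronger inhibition), compound 1 gives 148 nM, the lower of the two numbers available. Compound 2 gives 487 nM in this assay, and the gap between the two lies beyond the usual scatter of repeated measurements. The two compounds differ in more than one place, so the numbers alone do not tell which part of the structure carries the difference.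

Compound 3, `O=C1c2ccccc2S(=O)(=O)N1CCCCCN1CCN(c2cccc(C(F)(F)F)c2)CC1`, keeps the core of compound 1 and differs from it in a single place: trifluoromethyl in place of hydrogen on an aromatic carbon. For the measured compounds named here, no pair of measured compounds differing only in this way is available, so the size of the step is open. A step of modest size is expected, with direction uncertain, and it may well stay within the scatter. For compound 3 in this assay an inhibition constant of about 120 nM is estimated, with a range from 40 nM to 400 nM, which means an expected step of a 1.2-fold lower number from compound 1 to compound 3 (0.09 log units; within the scatter).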

Compound 3, inhibition constant: 35 nM
The estimate for compound 3 lay 3.4-fold (0.54 log units) above the measured number; the measured number lies below the stated range.
By their numbers in this assay, from the lowest: compound 3; then compound 1; then compound 2.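

Setting trifluoromethyl in place of hydrogen on an aromatic carbon, meta to a large group, gives a 4.2-fold lower number from compound 1 to compound 3 (0.63 log units; beyond the scatter) in this assay. For the compounds shown here, this is the first change that can be read on its own, and it shows that this position of the phenyl ring tolerates a group of 4 heavy atoms and that the number falls with it. Nothing shown bears on why the number falls.

From the compounds shown here alone, whether this step belongs to trifluoromethyl in particular or would also come with another group at this carbon, such as methoxy or nitrile, stays open. Going by these compounds, it is equally open whether the same change would give a step of similar size with the longer chain between the shared core and the piperazine.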